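This account rests on a few compounds, and the source may have more. Where it says the series, first, only, none or still open, it means among the compounds named here.

Compound 1 `CC(C)c1c(C(=O)N2CCCC2c2ccccc2)nn(-c2ccc(F)cc2)c1OC[C@@H](O)C[C@@H](O)CC(=O)O`: 14 nM
Compound 2 `Cc1ccc(CNC(=O)c2nn(-c3ccc(F)cc3)c(OC[C@@H](O)C[C@@H](O)CC(=O)O)c2C(C)C)cc1`: 15 nM

In an assay on microsomes from liver for inhibition of 3-hydroxy-3-methylglutaryl-coenzyme A reductase (Rattus norvegicus) (a lower number here means a stronger inhibitor, a higher number a weaker inhibitor), compound 1 gives 14 nM and compound 2 gives 15 nM. Compound 2 stands only as far from compound 1 as the step of a 1.1-fold higher number from compound 1 to compound 2 (0.03 log units; within the scatter), which is within the scatter, so the two numbers are not told apart. Compound 3 `COc1cccc(CNC(=O)c2nn(-c3ccc(F)cc3)c(OC[C@@H](O)C[C@@H](O)CC(=O)O)c2C(C)C)c1` differs from compound 2 by 3-methoxyphenyl in place of 4-methylphenyl on a saturated chain carbon bound to an amide-type nitrogen. Within the data shown here, no measured step concerns the 4-methylphenyl on a saturated chain carbon bound to an amide-type nitrogen. Among the measured compounds shown here, the one measured step, a 1.1-fold higher number from compound 1 to compound 2 (0.03 log units; within the scatter), exchanged the whole group on the carbonyl carbon and left the number inside the scatter; that is the only information on this part of the molecule, and it points to tolerance rather than to a shift. The expected step of no change at the digits printed from compound 2 to compound 3 (within the scatter) is therefore none beyond the scatter. Compound 3 is estimated at 15 nM, with a range from 7 nM to 32 nM.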

Compound 3, half-maximal inhibitory concentration: 16 nM
Compound 3: middle estimate off by 1.1-fold (0.03 log units), on the low side; measured number inside the range.
By their numbers in this assay, from the lowest: compounds 1, 2 and 3 (each within the scatter of the next).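

In this assay, among these compounds, 3-methoxyphenyl in place of 4-methylphenyl on a saturated chain carbon bound to an amide-type nitrogen gives a 1.1-fold higher number from compound 2 to compound 3 (0.03 log units; within the scatter), the first reading of a change confined to this aryl group, and it stays within the scatter. The larger exchange on the carbonyl carbon, (3-methoxybenzyl)amino in place of 2-phenylpyrrolidin-1-yl, gives a 1.1-fold higher number from compound 1 to compound 3 (0.06 log units; within the scatter), also within the scatter, so compounds 1, 2 and 3 cannot be ranked in this assay. Nothing available bears on why these numbers stay together.

The step from compound 2 to compound 3 exchanges methyl for methoxy and alters the printed ring locant together, so the two contributions remain unseparated. Still open, going by these compounds, are an unsubstituted benzyl, a carboxylic acid or an amine on the aryl ring, and a longer chain to that ring.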